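From Dichlorophenyl to Pyrrolyl on the Amide Carbonyl

This account rests on a few compounds, and the source may have more. Where it says the series, first, only, none or still open, it means among the compounds named here.

- Compound 1 `CN1CCN(c2cccc(N/C=C3\C(=O)Nc4ccc(NC(=O)c5c(F)cccc5F)cc43)c2)CC1`: 2030 nM
- Compound 2 `CN1CCN(c2cccc(N/C=C3\C(=O)Nc4ccc(NC(=O)c5c(Cl)cccc5Cl)cc43)c2)CC1`: 2140 nM

In a functional assay on A2780 cells (Homo sapiens) for inhibition, read by sulforhodamine B assay, with a stated time of 3 days (a lower number here means a stronger inhibitor, a higher number a weaker inhibitor), compound 2 gives 2140 nM, level with compound 1 within the scatter. Compound 3 `CN1CCN(c2cccc(N/C=C3\C(=O)Nc4ccc(NC(=O)c5ccc[nH]5)cc43)c2)CC1` differs from it as follows: 1H-pyrrol-2-yl in place of 2,6-dichlorophenyl on a carbonyl carbon. Going by the values given here, the only measured step that bears on this, a 1.1-fold higher number from compound 1 to compound 2 (0.02 log units; within the scatter), exchanged one 2,6-dihalophenyl group for another, so no measurement covers a change of the aromatic ring itself. With that uncertainty, a modest gain is expected, and the estimated change is a 2.1-fold lower number from compound 2 to compound 3 (0.33 log units; beyond the scatter). Compound 3 is estimated at 1000 nM, with an expected range from 200 nM to 4000 nM.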

Compound 3, half-maximal inhibitory concentration: 4460 nM
Compound 3: the middle estimate sits 4.5-fold (0.65 log units) below what was measured, and the stated range ends below it.
By their numbers in this assay, from the lowest: compounds 1 and 2 (each within the scatter of the next); then compound 3.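

In this assay the ring on this carbonyl carbon, whose other neighbour is the amide-type nitrogen, proves to matter where the exchange of one 2,6-dihalophenyl group for the other did not: 1H-pyrrol-2-yl gives a 2.1-fold higher number from compound 2 to compound 3 (0.32 log units; beyond the scatter) and a 2.2-fold higher number from compound 1 to compound 3 (0.34 log units; beyond the scatter). The change is modest, and compound 3 is the weakest inhibitor of the three. Nothing available explains this loss.

The compounds shown leave open whether the ring size, the missing halogens or the added hydrogen-bond donor drives the step. A plain phenyl or a furan-2-yl group on the same carbonyl carbon would help separate these.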